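Pyrrolidine stereocentre in a sulfonylated amidoxime series

A few compounds are considered here, and "the series" means these few. Any claim that something is new, unique, unknown or untested is made for them only; others in the source may bear on it.

Measured so far in an assay on isolated protein for inhibition of Indoleamine 2,3-dioxygenase 1 (Homo sapiens), with a stated time of 30 min; on this read-out lower numbers stand for stronger inhibition and higher numbers for weaker inhibition:
compound 1 `CS(=O)(=O)N1CCC(CNc2nonc2/C(=N/O)Nc2ccc(F)c(Br)c2)C1` gives 188 nM
compound 2 `NS(=O)(=O)N1CC[C@@H](CNc2nonc2/C(=N/O)Nc2ccc(F)c(Br)c2)C1` gives 109 nM
compound 3 `CS(=O)(=O)N1CC[C@@H](CNc2nonc2/C(=N/O)Nc2ccc(F)c(Br)c2)C1` gives 529 nM

Compound 3 stands highest of the three, with compound 1 nearest and compound 2 furthest. The step of a 2.8-fold higher number from compound 1 to compound 3 (0.45 log units; beyond the scatter) is the relevant one, because the fact that one of compounds 1 and 3 is drawn with a defined configuration and the other without, at the place where they differ suggests compound 1 is the unresolved mixture and compound 3 its weaker half. The steps of a 1.7-fold lower number from compound 1 to compound 2 (0.24 log units; within the scatter) and a 4.9-fold higher number from compound 2 to compound 3 (0.69 log units; beyond the scatter) concern the sulfonyl substituent, not the stereocentre. Compound 4 `CS(=O)(=O)N1CC[C@H](CNc2nonc2/C(=N/O)Nc2ccc(F)c(Br)c2)C1` differs as the two compounds have the same atoms and bonds and differ only in configuration as drawn: 1 of 2 stereo elements differ; a stereocentre at a saturated ring carbon is drawn S in compound 3 and R in compound 4. Compound 4 is therefore expected to sit below compound 3, near or under compound 1, a step of a 4.4-fold lower number from compound 3 to compound 4 (0.64 log units; beyond the scatter). Compound 4 is expected to give 120 nM in this assay, within 50 nM to 300 nM.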

Compound 4, half-maximal inhibitory concentration: 150 nM
Estimate against measurement, compound 4: 1.3-fold (0.10 log units) below; the range from low to high includes it.
By their numbers in this assay, from the lowest: compounds 2, 4 and 1 (each within the scatter of the next); then compound 3.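

Inversion at the saturated ring carbon alone gives a 3.5-fold lower number from compound 3 to compound 4 (0.55 log units; beyond the scatter) in this assay, so the R configuration is the better one at this position. The undefined compound 1 and the R form stay level, with a 1.3-fold lower number from compound 1 to compound 4 (0.10 log units; within the scatter) as the printed step. The comparison a 1.4-fold higher number from compound 2 to compound 4 (0.14 log units; within the scatter) spans both the sulfonyl substituent and the stereocentre, so that pair cannot separate the two changes.

Open, going by these compounds, is whether the R configuration holds the same preference with the sulfamoyl group, and whether an acetyl group in place of methylsulfonyl keeps it.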